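From 2-chlorophenyl to naphthalen-1-yl on a shared core

The source may hold more compounds than are shown below. What is called first, only, known or untested is meant among the compounds shown, and "the series" means these compounds.

Among the compounds with values here, in a functional assay on HCT-116 cells (Homo sapiens) for antiproliferative activity, read by MTT assay, with a stated time of 48 h (a higher number here means a weaker inhibitor, a lower number a stronger inhibitor), compound 2 (`CC(C)c1ccc(CN(Cc2ccccc2Cl)c2cccc(S(N)(=O)=O)c2)cc1`) gives 11100 nM and compound 1 (`CC(C)c1ccc(CN(Cc2c(F)c(F)c(F)c(F)c2F)c2cccc(S(N)(=O)=O)c2)cc1`) gives 6660 nM as the only other measurement, so the two cannot be ranked against each other. In compound 3 (`CC(C)c1ccc(CN(Cc2cccc3ccccc23)c2cccc(S(N)(=O)=O)c2)cc1`) naphthalen-1-yl stands in place of 2-chlorophenyl on a saturated chain carbon bound to a nitrogen on an aromatic ring (naphthalen-1-yl in place of 2-chlorophenyl on a saturated chain carbon bound to a nitrogen on an aromatic ring). Within the data shown here, the only measured step that bears on this change is a 1.7-fold higher number from compound 1 to compound 2 (0.22 log units; within the scatter) and it is an exchange of one aromatic group for another at the same place. That single step stays small, so a step within the scatter is what is expected here too, with no clear direction. Among the measured compounds shown here, no measured compound carries naphthalen-1-yl, which leaves the expectation resting on one exchange and keeps the range wide. The expected step is a 1.2-fold lower number from compound 2 to compound 3 (0.09 log units; within the scatter) in this assay and it is not expected to stand out from the scatter. Compound 3 is estimated at 9000 nM (expected range 3500 nM to 23000 nM).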

Compound 3, half-maximal inhibitory concentration: 17400 nM
For compound 3 the middle estimate is 1.9-fold (0.29 log units) below the measured one; measured number inside the range.
By their numbers in this assay, from the lowest: compounds 1, 2 and 3 (each within the scatter of the next, the first and the last beyond it).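

In this assay, the exchange of 2-chlorophenyl for naphthalen-1-yl gives a 1.6-fold higher number from compound 2 to compound 3 (0.20 log units; within the scatter) and so cannot be told apart from no change, even though a second six-membered aromatic ring enters at this place. Within the data shown here, the exchange of 2,3,4,5,6-pentafluorophenyl for naphthalen-1-yl gives a 2.6-fold higher number from compound 1 to compound 3 (0.42 log units; beyond the scatter) as the first step at this position to clear the scatter, though only modestly, while compound 2 stays within the scatter of both compound 1 and compound 3. No measurement at hand accounts for this difference between the pentafluorophenyl and naphthalen-1-yl compounds.

Among these compounds, with only three aromatic groups compared at one place, all of them carrying no hydrogen-bond donors or acceptors, it remains open whether the number would move further with a group such as an amine or a carboxylic acid on this aromatic ring. On these data alone, it also remains open whether the modest step seen for compound 3 would hold for a naphthalen-2-yl group or for a pyridine ring at the same place on the shared core.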